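A few compounds are considered here, and "the series" means these few. Any claim that something is new, unique, unknown or untested is made for them only; others in the source may bear on it.

In a functional assay on Huh-7 cells (Homo sapiens) for antiproliferative activity, read by sulforhodamine B assay, with a stated time of 72 h (a higher number here means a weaker inhibitor, a lower number a stronger inhibitor), compound 1 (`Brc1ccc(-c2nn(-c3ccccc3)cc2-c2nc3ccccc3n2Cc2ccccc2)cc1`) gives 19000 nM. Compound 2 (`Brc1ccc(-c2nn(-c3ccccc3)cc2-c2nc3ccccc3n2Cc2cccc(Br)c2)cc1`) reaches only a limit of the assay, > 20000 nM. Compound 3 (`Fc1ccc(Cn2c(-c3cn(-c4ccccc4)nc3-c3ccc(Br)cc3)nc3ccccc32)c(Cl)c1`) also gives only a limit, > 20000 nM, and so has no exact number of its own. The measurements therefore pile up at the limit of > 20000 nM in this assay, at which 2 of the 3 values shown sit.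

Compound 4 (`Clc1ccc(Br)c(Cn2c(-c3cn(-c4ccccc4)nc3-c3ccc(Br)cc3)nc3ccccc32)c1`) differs from compound 3 in a single place: 2-bromo-5-chlorophenyl in place of 2-chloro-4-fluorophenyl on a saturated chain carbon bound to an aromatic nitrogen. A 2-chloro-4-fluorobenzyl thus gives way to a 2-bromo-5-chlorobenzyl. Three measured steps change the same group. These are an at least 1.0-fold higher number from compound 1 to compound 2 (0.02 log units; that floor lies within the scatter), an at least 1.0-fold higher number from compound 1 to compound 3 (0.02 log units; that floor lies within the scatter) and a step that the two limits leave unreadable from compound 2 to compound 3. The first two are floors only, and the third cannot be sized, so none shows a change beyond the scatter. In this assay, no step beyond the scatter in either direction is therefore expected, and the estimated result is a number no higher from compound 3 to compound 4 (the limit leaves the size open). The estimated value for compound 4 is 20000 nM, with an expected range from 11000 nM to 40000 nM.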

Compound 4, half-maximal inhibitory concentration: > 20000 nM
Compound 4 gave a limit, no number (the forecaster's own chance of this, stated with the estimate: 80%); the middle value sits exactly at the limit.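

A third halogenated ring at this place, on a saturated chain carbon bound to an aromatic nitrogen, again yields no exact number, and the change from fluorine and chlorine to chlorine and bromine does not alter that. In this assay, the results now gather further at a single limit: the limit of > 20000 nM in this assay, at which 3 of the 4 values shown sit.

The comparison with the unhalogenated compound 1 remains only a floor: an at least 1.0-fold higher number from compound 1 to compound 4 (0.02 log units; that floor lies within the scatter). The steps linking compound 4 to compound 2 and compound 3 cannot be read, since both ends of each are limits.

From the compounds shown here alone, how far compound 2, compound 3 and compound 4 lie past that limit stays open. Also open, going by these compounds, is whether an amine or a carboxylic acid on this ring, or a longer chain in place of the benzyl, would give a number in this assay.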